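The source may report more compounds than this note shows. Statements on the series, on what has been measured and on what is new or still open speak of the compounds shown alone.

Compound 1, `CCn1c(=O)/c(=C2\Sc3ccccc3N2C)s/c1=C\c1ccncc1Nc1ccccc1C`, gives 470 nM in a functional assay on CWR22R cells (Homo sapiens) for inhibition; a higher number here means a weaker inhibitor, a lower number a stronger inhibitor.
Compound 2, `CCn1c(=O)/c(=C2\Sc3ccc(OC)cc3N2C)s/c1=C\c1ccncc1Nc1ccccc1C`, gives 410 nM in this assay.

For the measured compounds named here, compound 2 has the lower of the two numbers in this assay, but its only neighbour lies within the scatter, as a 1.1-fold lower number from compound 1 to compound 2 (0.06 log units; within the scatter) shows. Compound 3, `CCn1c(=O)/c(=C2\Sc3ccc(C)cc3N2C)s/c1=C\c1ccncc1Nc1ccccc1C`, differs from compound 2 by methyl in place of methoxy on an aromatic carbon. Going by the values given here, the one measured step at this same carbon, a 1.1-fold lower number from compound 1 to compound 2 (0.06 log units; within the scatter), stayed within the scatter, so no step beyond the scatter is expected for compound 3 in this assay, a 1.0-fold higher number from compound 2 to compound 3 (0.02 log units; within the scatter). Compound 3 is therefore estimated at 430 nM, with a range from 200 nM to 900 nM.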

Compound 3, half-maximal inhibitory concentration: 480 nM
Compound 3: middle estimate off by 1.1-fold (0.05 log units), on the low side, and the stated range covers the measured number.
By their numbers in this assay, from the lowest: compounds 2, 1 and 3 (each within the scatter of the next).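

At this aromatic carbon, methyl in place of methoxy leaves the reading in this assay within the scatter (a 1.2-fold higher number from compound 2 to compound 3 (0.07 log units; within the scatter)), and so does methyl in place of hydrogen (a 1.0-fold higher number from compound 1 to compound 3 (0.01 log units; within the scatter)). Hydrogen, methyl and methoxy therefore cannot be told apart here, whether or not the group carries a hydrogen-bond acceptor. The data on hand offer no explanation for this.

As far as these compounds go, it remains open whether an amine, a carboxylic acid or a longer chain such as butoxy at this carbon would also stay within the scatter. The same question stands for changes elsewhere on the shared core.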